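This account rests on a few compounds, and the source may have more. Where it says the series, first, only, none or still open, it means among the compounds named here.

Four compounds share one core. Compound 1 `Clc1ccc(Cc2nn3c(Br)c(-c4ccccc4)nc3s2)cc1` carries a bromo group and a phenyl group on that core. In a functional assay on L1210 cells (Mus musculus) for cytotoxicity, with a stated time of 48 h (a lower number here means a stronger inhibitor, a higher number a weaker inhibitor), compound 1 reaches only a limit of the assay, > 250000 nM, which is a limit rather than a number (the limit of > 250000 nM in this assay, at which 1 of the 3 values shown sits). Compound 2 `O=[N+]([O-])c1ccc(-c2nc3sc(Cc4ccc(Cl)cc4)nn3c2Br)cc1` differs from compound 1 by nitro in place of hydrogen on an aromatic carbon. In this assay compound 2 gives 94000 nM, so this change made an at least 2.6-fold lower number from compound 1 to compound 2 (0.42 log units; beyond the scatter). Compound 3 `O=Cc1c(-c2ccccc2)nc2sc(Cc3ccc(Cl)cc3)nn12` has a different core, differing from compound 1 by formyl in place of bromo on an aromatic carbon. In this assay compound 3 gives 20000 nM, a step of an at least 12-fold lower number from compound 1 to compound 3 (1.09 log units; beyond the scatter). Among the measured compounds shown here, compound 4 `O=Cc1c(-c2ccc([N+](=O)[O-])cc2)nc2sc(Cc3ccc(Cl)cc3)nn12` is not yet measured; it differs from compound 3 by nitro in place of hydrogen on an aromatic carbon, the same change at the same place as the one between compound 1 and compound 2. Compound 4 is expected to give 8000 nM, within 2000 nM to 30000 nM. Going by these compounds, the expected step of a 2.5-fold lower number from compound 3 to compound 4 (0.40 log units; beyond the scatter) is estimated in the same direction as an at least 2.6-fold lower number from compound 1 to compound 2 (0.42 log units; beyond the scatter), though that earlier step started from a limit, so its true size is unknown and the estimate is kept cautious.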

Compound 4, half-maximal inhibitory concentration: 15000 nM
Compound 4: middle estimate off by 1.9-fold (0.27 log units), on the low side; the measured number falls inside the stated range.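

In this assay, nitro in place of hydrogen gives a 1.3-fold lower number from compound 3 to compound 4 (0.12 log units; within the scatter), so on the core of compound 3 this change does not stand out from the scatter, and whether it truly behaves differently on the two cores stays undecided: the same change on two cores in this assay, an at least 2.6-fold lower number (0.42 log units; beyond the scatter) from compound 1 to compound 2 and a 1.3-fold lower number (0.12 log units; within the scatter) from compound 3 to compound 4; the limit leaves it open whether they differ

Formyl in place of bromo holds its direction on the nitro-bearing pair, with a 6.3-fold lower number from compound 2 to compound 4 (0.80 log units; beyond the scatter), but a difference in size between the two cores cannot be established: the same change on two cores in this assay, an at least 12-fold lower number (1.09 log units; beyond the scatter) from compound 1 to compound 3 and a 6.3-fold lower number (0.80 log units; beyond the scatter) from compound 2 to compound 4; the limit leaves it open whether they differ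

Both earlier steps start from compound 1, whose > 250000 nM is a limit and not a number, so they do not show how large either change really was there.

The compounds shown leave open whether another group in place of formyl, such as a carboxylic acid or an amine, would also give a lower number than bromo. They also leave open whether an amine in place of nitro on the phenyl ring would give a step beyond the scatter on either core.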